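This account rests on a few compounds, and the source may have more. Where it says the series, first, only, none or still open, it means among the compounds named here.

Compound 1, `COc1ccc(Cn2c(CCc3ccccc3)nnc2[C@H](NC(=O)C(C)(C)N)c2c[nH]c3ccccc23)c(OC)c1`, gives 17 nM in a functional assay on CHO cells for antagonist activity at growth hormone secretagogue receptor type 1 (Homo sapiens); a lower number here means a stronger inhibitor, a higher number a weaker inhibitor.
Compound 2, `COc1ccc(Cn2c(CCc3ccccc3)nnc2[C@H](NC(=O)c2ccncc2)c2c[nH]c3ccccc23)c(OC)c1`, gives 93 nM in this assay.
Compound 3, `COc1ccc(Cn2c(CCc3c[nH]c4ccccc34)nnc2[C@H](NC(=O)c2cnccn2)c2c[nH]c3ccccc23)c(OC)c1`, gives 97 nM in this assay.

Compound 3 stands at the high end of these three numbers; its value and that of compound 2 lie within the scatter of each other, while compound 1 sits markedly lower. Compound 4, `COc1ccc(Cn2c(CCc3ccccc3)nnc2[C@H](NC(=O)c2cnccn2)c2c[nH]c3ccccc23)c(OC)c1`, is not yet measured. It differs from compound 3 by phenyl in place of 1H-indol-3-yl on a saturated chain carbon, two bonds along the chain from an aromatic carbon. Among the compounds with values here, only one single-point step is known among the measured compounds, a 5.5-fold higher number from compound 1 to compound 2 (0.74 log units; beyond the scatter), and that step concerns the group on the carbonyl carbon, not the chain, so it does not bear on the present change. Compound 2 and compound 3 differ in two places at once, the chain end being one of them, and their values fall within the scatter, which gives no sign of a shift from that part of the molecule. Within the data shown here, with no direct precedent, no step beyond the scatter is expected for compound 4, a 1.1-fold lower number from compound 3 to compound 4 (0.03 log units; within the scatter). The estimate for compound 4 in this assay is therefore 90 nM, with a range from 30 nM to 270 nM.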

Compound 4, antagonist equilibrium constant: 24 nM
Compound 4: middle estimate off by 3.8-fold (0.57 log units), on the high side, and the stated range ends above it.
By their numbers in this assay, from the lowest: compounds 1 and 4 (each within the scatter of the next); then compounds 2 and 3 (each within the scatter of the next).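

The chain end does matter in this assay: phenyl in place of 1H-indol-3-yl, cut one bond further out phenethyl in place of 2-(1H-indol-3-yl)ethyl, gives a step that no pair differing in one place had shown (a 4.0-fold lower number from compound 3 to compound 4 (0.61 log units; beyond the scatter)). With phenethyl as the chain, the group on the carbonyl carbon can also be compared: pyrazin-2-yl in place of pyridin-4-yl gives a clear step (a 3.9-fold lower number from compound 2 to compound 4 (0.59 log units; beyond the scatter)), whereas pyrazin-2-yl in place of 1-amino-1-methylethyl leaves the number within the scatter (a 1.4-fold higher number from compound 1 to compound 4 (0.15 log units; within the scatter)). No measurement shown here explains any of these steps.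

As far as these compounds go, the phenyl-for-1H-indol-3-yl step is known only with pyrazin-2-yl on the carbonyl carbon, so its size with pyridin-4-yl or 1-amino-1-methylethyl there remains open. Also open, from the compounds shown here alone, is how a longer chain ending in phenyl, or a carboxylic acid at the chain end, would read in this assay.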